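Adding a Methyl Group to the Phenyl of Compound 2

The source may hold more compounds than are shown below. What is called first, only, known or untested is meant among the compounds shown, and "the series" means these compounds.

Measured in a functional assay on MCF7 cells (Homo sapiens) for antiproliferative activity, read by MTT assay, with a stated time of 72 h; on this read-out lower numbers stand for stronger inhibition and higher numbers for weaker inhibition:
- compound 1 `O=C1C=C(N2CCN(c3ccccc3Cl)CC2)C(=O)c2ccccc21`: 10300 nM
- compound 2 `O=C1C=C(N2CCC(c3ccccc3)CC2)C(=O)c2c(O)cccc21`: 8800 nM

The two compounds differ in more than one place, and their values lie within the usual scatter of each other. In this assay, compound 2 at 8800 nM therefore cannot be separated from compound 1 at 10300 nM. Both are measured only in the micromolar range, and two values give little basis for a trend.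

The next compound is compound 3 `Cc1ccccc1C1CCN(C2=CC(=O)c3cccc(O)c3C2=O)CC1`, which is still to be measured. It departs from compound 2 by a single change: methyl in place of hydrogen on an aromatic carbon. A methyl takes the place of hydrogen on an aromatic carbon, ortho to a large group, turning phenyl into 2-methylphenyl.

For the measured compounds named here, no measured pair shows this change, so the data offer no direct guide to its effect. The expectation in this assay therefore starts from compound 2 at 8800 nM, with no shift beyond the scatter in either direction. The expected change is a 1.2-fold lower number from compound 2 to compound 3 (0.07 log units; within the scatter). For compound 3 the estimated value is 7500 nM, with an expected range of 3000 nM to 18000 nM.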

Compound 3, half-maximal inhibitory concentration: 8900 nM
Compound 3: middle estimate off by 1.2-fold (0.07 log units), on the low side; low and high end bracket the measured number.
By their numbers in this assay, from the lowest: compounds 2, 3 and 1 (each within the scatter of the next).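

In this assay, for the compounds shown here, the step from phenyl to 2-methylphenyl is a 1.0-fold higher number from compound 2 to compound 3 (0.00 log units; within the scatter), which gives the first pair of compounds here that differ in one place. It shows that a methyl on this aromatic carbon, ortho to a large group, does not separate compound 3 from compound 2, and compound 3 at 8900 nM stays in the micromolar range. No accompanying measurement bears on this result, and the pair alone offers no account of it.

What the compounds shown leave open is whether a different group at this same place, such as a chlorine atom, a methoxy group, an amine or a carboxylic acid, would give a step beyond the scatter. Also open, from the compounds shown here alone, is whether a longer chain such as ethyl or propyl in place of the methyl would still leave the value of the new compound inseparable from that of compound 2 in this assay, since a single added methyl gives only one point at this place.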